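A few compounds are considered here, and "the series" means these few. Any claim that something is new, unique, unknown or untested is made for them only; others in the source may bear on it.

Of the compounds shown here, three have so far been measured in an ADME assay on MCF-10A cells (Homo sapiens) for cytotoxicity, read by MTT assay, with a stated time of 72 h (a lower number here means a stronger inhibitor of growth, a higher number a weaker inhibitor of growth), none of which differ from one another in a single place. Compound 1, `CS/C(=N\C(=O)c1cc(-c2ccccc2)nc2ccccc12)NC(=O)c1cc(-c2ccccc2)nc2ccccc12`, gives 540 nM in this assay. Compound 3, `CS/C(=N\C(=O)c1csc([N+](=O)[O-])c1)NC(=O)c1csc([N+](=O)[O-])c1`, gives 21400 nM. Compound 2, `C[Se]/C(=N\C(=O)c1cnc2ccccc2c1)NC(=O)c1cnc2ccccc2c1`, gives 52100 nM, the highest of the three numbers: its nearest neighbour is compound 3, whose number lies beyond the scatter below it, and its furthest is compound 1, which stands far below it. Compound 2 is therefore the weakest inhibitor of growth among the compounds measured.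

Compound 4, `O=C(/N=C(/NC(=O)c1cnc2ccccc2c1)[Se]Cc1ccccc1)c1cnc2ccccc2c1`, has not yet been measured. It differs from compound 2 in one place: phenyl in place of hydrogen on a saturated chain carbon bound to a selenium atom. Among the measured compounds shown here, no measured pair shows this change, so its effect on this assay is open.

For the measured compounds named here, with no measured step to lean on, only a modest expectation can be formed. The number for compound 4 is expected to move somewhat downward from that of compound 2, the estimated step being a 2.6-fold lower number from compound 2 to compound 4 (0.42 log units; beyond the scatter), though a result within the scatter would not surprise. Compound 4 is thus estimated at 20000 nM in this assay, with a range from 5000 nM to 80000 nM.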

Compound 4, concentration for total growth inhibition: > 100000 nM
Compound 4: only a limit was reported (the forecaster's own chance of this, stated with the estimate: 5%); at least 5.0-fold (0.69 log units) between middle value and limit.
By their numbers in this assay, from the lowest: compound 1; then compound 3; then compound 2. At a limit, above all of these: compound 4.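

For the first time, the compounds shown give a reading for a change on the saturated chain carbon bound to a selenium atom: in this assay, going from methyl to benzyl gives an at least 1.9-fold higher number from compound 2 to compound 4 (0.28 log units; that floor lies within the scatter). Compound 4 gives > 100000 nM, which is a limit of the assay and not a number. Phenyl at this place therefore brings no move towards stronger inhibition of growth, but the rise itself is not established beyond the scatter, and the reading is bounded on one side only: the limit of > 100000 nM in this assay, at which 1 of the 4 values shown sits.

Going by these compounds, how far the number of compound 4 lies past that limit stays open, and a single step cannot show whether the result belongs to phenyl itself or to the larger chain on selenium, nor whether it would carry over to the cores of compound 1 or compound 3. Also open, on these data alone, is what a smaller or differently built group at this place would do, such as an ethyl chain, an amine or a carboxylic acid on the chain carbon bound to the selenium atom.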